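Ester variation on a dihydropyrimidinone series at adenosine A2b

The source may report more compounds than this note shows. Statements on the series, on what has been measured and on what is new or still open speak of the compounds shown alone.

Of the compounds shown here, three of a shared core have been measured in an assay on membranes from HEK293 cells for displacement of a labelled ligand from adenosine receptor A2b (Homo sapiens), read by scintillation counting, with a stated time of 30 min, tested at 1 uM; a higher number here means more inhibition at the concentration tested (going by the name of the read-out), a lower number less inhibition. Compound 1 `CCC(CC)OC(=O)C1=C(C)NC(=O)NC1c1ccco1` gives 35%. Compound 2 `CC1=C(C(=O)OC2CCCCC2)C(c2ccco2)NC(=O)N1` gives 1%. Compound 3 `CCC(CC)OC(=O)C1=C(C)NC(=O)NC1c1ccoc1` gives 28%.

The two changes that connect these compounds behave differently. The change cyclohexyl in place of pentan-3-yl on an oxygen next to a carbonyl group produces the step of a number 34 percentage points lower from compound 1 to compound 2 (beyond the scatter), a drop well beyond the scatter. The change (furan-3-yl in place of furan-2-yl on a saturated ring carbon), which joins the same atoms differently and so describes how the core of compound 1 differs from the core of compound 3, produces only a number 7 percentage points lower from compound 1 to compound 3 (within the scatter), so compound 1 and compound 3 cannot be ordered against each other. Compound 3 stands apart from compound 2 only, by a gap beyond the scatter.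

Compound 4 `CC1=C(C(=O)OC2CCCCC2)C(c2ccoc2)NC(=O)N1` is not yet measured. It carries the change (cyclohexyl in place of pentan-3-yl on an oxygen next to a carbonyl group). This is the same change as from compound 1 to compound 2, at a place that reads identically in both pairs. For the measured compounds named here, because a number 34 percentage points lower from compound 1 to compound 2 (beyond the scatter) is the only precedent for this change, the expectation for compound 4 is a step of about a number 26 percentage points lower from compound 3 to compound 4 (beyond the scatter) from compound 3. The starting value of compound 3 leaves little room for a drop of that size, so the expectation for compound 4 in this assay is an inhibition near the floor, estimated at 2%, with a range from 0% to 12%. Whether the drop is as large as for the furan-2-yl pair rests on a single precedent.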

Compound 4, a percentage reported as inhibition, at one concentration (the size of the read-out at that concentration, not a potency): 4%
Estimate against measurement, compound 4: 2 percentage points below, within the range that was stated.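

In this assay, cyclohexyl in place of pentan-3-yl on an oxygen next to a carbonyl group carries over to the furan-3-yl compounds, giving a number 24 percentage points lower from compound 3 to compound 4 (beyond the scatter), and this step does not differ from the one seen with furan-2-yl: the same change on two cores in this assay, a number 34 percentage points lower (beyond the scatter) from compound 1 to compound 2 and a number 24 percentage points lower (beyond the scatter) from compound 3 to compound 4, 10 percentage points apart, within the scatter of two such steps. Furan-3-yl in place of furan-2-yl, now read on the cyclohexyl ester, gives a number 3 percentage points higher from compound 2 to compound 4 (within the scatter), so this change remains unresolved on both esters: the same change on two cores in this assay, a number 7 percentage points lower (within the scatter) from compound 1 to compound 3 and a number 3 percentage points higher (within the scatter) from compound 2 to compound 4, 10 percentage points apart, within the scatter of two such steps. These two pairs do not show that the ester change would carry to any other core. Compound 2 and compound 4 both lie close to the bottom of the read-out, so any further loss in them could hardly be seen.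

Going by these compounds, it remains open whether the loss follows the ring of the cyclohexyl group or would also appear with a cyclopentyl group or a longer open chain such as heptan-4-yl on the same oxygen. On these data alone, it is also open how a thiophen-2-yl or phenyl group in place of the furan on the saturated ring carbon would read against compound 1 at 35%.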